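The compounds below may be only part of what the source reports. "The series", "measured", "known", "first", "only" and "open" are said of these compounds alone.

Notes on the series in a functional assay on MT4 cells (Homo sapiens) for antiproliferative activity; a higher number here means that more compound is tolerated, a lower number that less compound is tolerated: compound 1 (`Cc1cn(C2OC(CO[Si](C)(C)C(C)(C)C)C3(OS(=O)(=O)C=C3N)C2O[Si](C)(C)C(C)(C)C)c(=O)n(CCCNC(=O)[C@@H]2CCCN2C(=O)[C@H](C)N)c1=O`) gives 20000 nM and compound 2 (`Cc1cn(C2OC(CO[Si](C)(C)C(C)(C)C)C3(OS(=O)(=O)C=C3N)C2O[Si](C)(C)C(C)(C)C)c(=O)n(CCCNC(=O)[C@@H]2CCCN2C(=O)[C@@H](N)CC(N)=O)c1=O`) gives 22000 nM as the only two numbers in hand, and the two stand level within the scatter. The change to compound 3 (`Cc1cn(C2OC(CO[Si](C)(C)C(C)(C)C)C3(OS(=O)(=O)C=C3N)C2O[Si](C)(C)C(C)(C)C)c(=O)n(CCCNC(=O)[C@@H]2CCCN2C(=O)[C@@H](N)CCC(=O)O)c1=O`) puts carboxymethyl in place of carbamoyl on a saturated chain carbon, two bonds along the chain from an amine nitrogen and a carbonyl carbon. Going by the values given here, one measured step bears on it, carbamoyl in place of hydrogen at that same place, and it amounts to a 1.1-fold higher number from compound 1 to compound 2 (0.04 log units; within the scatter) and so offers no measured change to carry forward. Among the compounds with values here, no measured compound carries carboxymethyl, and a single step is thin evidence. A step beyond the scatter is therefore not expected in this assay and no direction is favoured. The expected step is a 1.1-fold lower number from compound 2 to compound 3 (0.04 log units; within the scatter) on this reading. For compound 3 the estimated value is 20000 nM with an expected range of 9000 nM to 45000 nM for a measurement in this series.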

Compound 3, half-maximal cytotoxic concentration: 64000 nM
Beside the measured number, compound 3's estimate is 3.2-fold (0.51 log units) below it, outside the stated range (above it).
By their numbers in this assay, from the lowest: compounds 1 and 2 (each within the scatter of the next); then compound 3.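

In this assay, the earlier step from hydrogen to carbamoyl gave no change that could be read, so this position could have seemed indifferent to what it carries. The new result shows that it is not: the exchange of carbamoyl for carboxymethyl, seen in full as carbamoylmethyl to 2-carboxyethyl, gives a 2.9-fold higher number from compound 2 to compound 3 (0.46 log units; beyond the scatter), and the comparison with the hydrogen-bearing side gives a 3.2-fold higher number from compound 1 to compound 3 (0.51 log units; beyond the scatter), so both modest steps run towards more compound being tolerated and compound 3 stands apart from the other two. Nothing at hand gives a measured reason for this shift.

The change alters the end group and the chain length together, so the shift cannot yet be assigned to either, and a carboxylic acid on the shorter chain of compound 2 or a carbamoyl group on the longer chain of compound 3 would separate the two. As far as these compounds go, whether a still longer carboxylic acid chain, or an amine at the end of the chain, would move the number further also remains open.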